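The source may report more compounds than this note shows. Statements on the series, on what has been measured and on what is new or still open speak of the compounds shown alone.

Values measured in a functional assay on HL-60 cells (Homo sapiens) for inhibition, read by CCK-8 assay, with a stated time of 48 h; on this read-out lower numbers stand for stronger inhibition and higher numbers for weaker inhibition:

- compound 1 `COc1ccc(NC(=O)NCCNS(=O)(=O)c2sccc2-c2ccc(C)cc2Oc2ccc(O)c(O)c2)cc1`: 6100 nM
- compound 2 `O=C(NCCNS(=O)(=O)c1ccc(-c2ccccc2Oc2ccc([N+](=O)[O-])c([N+](=O)[O-])c2)s1)Nc1cc(Cl)cc(Cl)c1`: 2300 nM
- compound 3 `COc1ccc(Oc2ccccc2-c2ccsc2S(=O)(=O)NCCNC(=S)Nc2cc(C(F)(F)F)cc(C(F)(F)F)c2)cc1OC`: 2800 nM

Compound 1 gives the highest of these three numbers, and its gaps to compound 2 and compound 3 both lie beyond the scatter. Going by the values given here, the three compounds differ in several places at once, so no measured pair isolates a single change.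

The next compound to be tested is compound 4 `Cc1ccc(-c2ccsc2S(=O)(=O)NCCNC(=S)Nc2cccc([N+](=O)[O-])c2)c(Oc2ccc(O)c(O)c2)c1`. It keeps the core of compound 1 and differs only on an amine nitrogen whose other neighbours are a saturated chain carbon: a group of 12 heavy atoms (7 carbon, 2 nitrogen, 2 oxygen, 1 sulfur; one six-membered aromatic ring of carbon only) in place of a group of 11 heavy atoms (8 carbon, 1 nitrogen, 2 oxygen; one six-membered aromatic ring of carbon only), on an amine nitrogen.

Among the compounds with values here, with no direct precedent for this exchange, the only guide is the narrow spread of the measured values. Compound 1 stands at the top of that spread at 6100 nM, and compound 3 stands lower at 2800 nM. A small step toward a lower number in this assay is therefore expected, probably within the scatter, although a step in the other direction cannot be excluded.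

The estimate corresponds to an expected 1.7-fold lower number from compound 1 to compound 4 (0.24 log units; within the scatter).

For compound 4 the estimated value is 3500 nM, with an expected range of 1500 nM to 8000 nM.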

Compound 4, half-maximal inhibitory concentration: 3400 nM
For compound 4 the middle estimate is 1.0-fold (0.01 log units) above the measured one; the range from low to high includes it.
By their numbers in this assay, from the lowest: compounds 2, 3, 4 and 1 (each within the scatter of the next, the first and the last beyond it).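

In this assay, placing the group of 12 heavy atoms on the amine nitrogen in place of the (4-methoxyphenyl)carbamoyl group gives a 1.8-fold lower number from compound 1 to compound 4 (0.25 log units; within the scatter) on the otherwise unchanged core of compound 1. This pair is the first among the compounds shown to differ in one place, so this exchange can now be read on its own, whereas the earlier compounds differed in several places at once. Both groups hold one six-membered aromatic ring of carbon only, and the exchange, which brings in sulfur and a second nitrogen, leaves the read-out within the usual scatter of repeated measurements, while no measurement available here accounts for this outcome.

Going by these compounds alone, what the compounds leave open is how far this tolerance extends, since only one exchange at this position can be read, and it keeps an aromatic ring on the amine nitrogen. A small acetyl group, a plain hexyl chain or a group ending in a carboxylic acid on that nitrogen might behave quite differently, and the shared core of compound 1 would still offer no guide to such a result.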